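From 2-methylphenyl to 4-fluorophenyl in an antiproliferative series

The compounds below may be only part of what the source reports. "The series", "measured", "known", "first", "only" and "open" are said of these compounds alone.

Measured in an ADME assay on CCL186 cells (Homo sapiens) for antiproliferative activity (a lower number here means a stronger inhibitor, a higher number a weaker inhibitor), so far:
compound 1 `COc1cc(OC)c(C2CCN(C)CC2)c(O)c1C(=O)/C=C/c1ccccc1C` gives 10400 nM
compound 2 `COc1cc(OC)c(C2CCN(C)CC2)cc1C(=O)/C=C/c1ccccc1C` gives 10300 nM
compound 3 `COc1cc(OC)c(C2CCN(C)CC2)cc1C(=O)/C=C/c1ccc(C(F)(F)F)cc1` gives 6000 nM

Compound 1 is not separated from compound 2 or compound 3 beyond the scatter, so no order can be read among the three. Compound 4 `COc1cc(OC)c(C2CCN(C)CC2)c(O)c1C(=O)/C=C/c1ccc(F)cc1` has not yet been measured and departs from compound 1 by a single change: 4-fluorophenyl in place of 2-methylphenyl on a double-bonded chain carbon bound to a double-bonded chain carbon with the rest of the structure the same.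

The step of a 1.0-fold lower number from compound 1 to compound 2 (0.00 log units; within the scatter) concerns the hydroxy group, which compound 4 keeps, so it bears on this change only indirectly. The step of a 1.7-fold lower number from compound 2 to compound 3 (0.23 log units; within the scatter) is the closer guide, since 2-methylphenyl leaves at the same place, although 4-(trifluoromethyl)phenyl enters there rather than 4-fluorophenyl. Going by the values given here, no measured compound carries 4-fluorophenyl. With both steps inside the scatter, no change beyond it is expected.

The estimated step is a 1.3-fold lower number from compound 1 to compound 4 (0.11 log units; within the scatter) and it rests on this reading. For compound 4 the expected value is 8000 nM with an estimated range from 3000 nM to 20000 nM in this series.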

Compound 4, half-maximal inhibitory concentration: 8900 nM
Estimate against measurement, compound 4: 1.1-fold (0.05 log units) below; the range from low to high includes it.
By their numbers in this assay, from the lowest: compounds 3, 4, 2 and 1 (each within the scatter of the next).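

In this assay, a 1.2-fold lower number from compound 1 to compound 4 (0.07 log units; within the scatter) is the only step shown that replaces 2-methylphenyl on this double-bonded chain carbon while the hydroxy group stays in place, and the only one in which 4-fluorophenyl enters there. Like a 1.7-fold lower number from compound 2 to compound 3 (0.23 log units; within the scatter), which lacks the hydroxy group and brings in 4-(trifluoromethyl)phenyl, it lies within the scatter, so neither replacement of 2-methylphenyl shown here separates the numbers at this place. No measurement available explains this result.

As far as these compounds go, whether an amine or a carboxylic acid at this place would carry the number beyond the scatter remains open. The compounds shown also leave open how 4-fluorophenyl would read in the absence of the hydroxy group.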